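The source may report more compounds than this note shows. Statements on the series, on what has been measured and on what is new or still open speak of the compounds shown alone.

Measured compounds in an assay on isolated protein for inhibition of Amine oxidase [flavin-containing] A (Homo sapiens), read by spectrophotometry; a lower number here means a stronger inhibitor, a higher number a weaker inhibitor:
compound 1 `Clc1ccccc1/C=N/Nc1nc2ccccc2nc1Cc1ccccc1` gives 5.8 nM
compound 2 `COc1ccc(/C=N/Nc2nc3ccccc3nc2Cc2ccccc2)cc1` gives 63 nM
compound 3 `CN(C)c1ccc(/C=N/Nc2nc3ccccc3nc2Cc2ccccc2)cc1` gives 83 nM

Compound 1 has the lowest number of the three. Its nearest neighbour is compound 2, with an 11-fold higher number from compound 1 to compound 2 (1.04 log units; beyond the scatter), and compound 3 lies furthest, with a 14-fold higher number from compound 1 to compound 3 (1.16 log units; beyond the scatter). Between compound 2 and compound 3 the step is a 1.3-fold higher number from compound 2 to compound 3 (0.12 log units; within the scatter), so the two substituted-phenyl analogues are not separated.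

Compound 4 `C/C(=N\Nc1nc2ccccc2nc1Cc1ccccc1)c1ccccn1` is not yet measured. It differs from compound 1 as follows: a group of 9 heavy atoms (7 carbon, 2 nitrogen; one six-membered aromatic ring with 1 hetero atom) in place of a group of 9 heavy atoms (7 carbon, 1 nitrogen, 1 chlorine; one six-membered aromatic ring of carbon only), on a nitrogen on an aromatic ring. Both measured steps from compound 1 replace the 2-chlorophenyl on the carbon with a double bond to nitrogen, and both are large increases, an 11-fold higher number from compound 1 to compound 2 (1.04 log units; beyond the scatter) and a 14-fold higher number from compound 1 to compound 3 (1.16 log units; beyond the scatter). Among the measured compounds shown here, the step to compound 4 also removes that group, but the entering group has no counterpart among the measured compounds, so its own effect is unknown. The expectation in this assay is therefore a rise of similar order, a 6.9-fold higher number from compound 1 to compound 4 (0.84 log units; beyond the scatter), with wide uncertainty. Compound 4 is expected to give 40 nM, in the range 8 nM to 200 nM.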

Compound 4, half-maximal inhibitory concentration: 91 nM
Compound 4: the middle estimate sits 2.3-fold (0.36 log units) below what was measured; the range from low to high includes it.
By their numbers in this assay, from the lowest: compound 1; then compounds 2, 3 and 4 (each within the scatter of the next).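

In this assay, exchanging the whole group on the nitrogen gives a 16-fold higher number from compound 1 to compound 4 (1.20 log units; beyond the scatter), so a third replacement of the group in compound 1 also ends far from it, this time with a six-membered aromatic ring with 1 hetero atom instead of a substituted ring of carbon only. Loss of the 2-chlorophenyl group therefore goes with a large rise for both ring types shown, no compound here goes against this, and compounds 2, 3 and 4 stand each within the scatter of the next. No available evidence bears on the reason for this step.

The entering group of compound 4 differs from the leaving group in more than its ring, so the share of the ring hetero atom in the step stays unresolved. On these data alone, whether the low number of compound 1 rests on the chlorine itself is also open: an unsubstituted phenyl or a bromophenyl group on the carbon with a double bond to nitrogen would be the direct comparison.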